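The source may hold more compounds than are shown below. What is called first, only, known or untested is meant among the compounds shown, and "the series" means these compounds.

Compound 1, `CCCCCCCCC(=O)c1cc(O)c(O)c(O)c1`: in a functional assay on CCRF-CEM cells (Homo sapiens) for cytotoxicity, read by MTT assay, with a stated time of 72 h (a lower number here means a stronger inhibitor, a higher number a weaker inhibitor), compound 1 gives 43000 nM.
Compound 2, `CCCCCCCCCCC(=O)c1cc(O)c(O)c(O)c1`: in this assay compound 2 gives 20000 nM.

Compound 2 holds the lowest number of the two, with compound 1 the nearest at a higher value. Compound 3, `CCCCCCCCCCCC(=O)c1cc(O)c(O)c(O)c1`, differs from compound 2 by methyl in place of hydrogen on a saturated chain carbon, ten or more bonds along the chain from a carbonyl carbon. Within the data shown here, the one step that bears on this is a 2.2-fold lower number from compound 1 to compound 2 (0.33 log units; beyond the scatter), which went the same way with a larger added group. A smaller step in the same direction is therefore expected in this assay, roughly a 1.4-fold lower number from compound 2 to compound 3 (0.15 log units; within the scatter). Compound 3 is estimated at 14000 nM, within 7000 nM to 35000 nM.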

Compound 3, half-maximal inhibitory concentration: 31800 nM
Compound 3: middle estimate off by 2.3-fold (0.36 log units), on the low side; the range from low to high includes it.
By their numbers in this assay, from the lowest: compounds 2, 3 and 1 (each within the scatter of the next, the first and the last beyond it).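

In this assay, adding methyl in place of hydrogen on a saturated chain carbon gives a 1.6-fold higher number from compound 2 to compound 3 (0.20 log units; within the scatter), a difference that cannot be told apart from repeat measurement. The other comparison gives a 1.4-fold lower number from compound 1 to compound 3 (0.13 log units; within the scatter), so compound 3 does not follow the step seen between compound 1 and compound 2, and these compounds show no steady trend with chain length. Nothing available explains these numbers. On these data alone, whether a longer chain would separate from compound 2 remains open, as does what an amine or a carboxylic acid at the chain end would do.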